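Thiourea in Place of Benzyl on a Fused Core

The source may report more compounds than this note shows. Statements on the series, on what has been measured and on what is new or still open speak of the compounds shown alone.

Measured compounds, all in a functional assay on MKN-74 cells (Homo sapiens) for antiproliferative activity, with a stated time of 24 h; on this read-out higher numbers stand for weaker inhibition and lower numbers for stronger inhibition:
compound 1, `NC(=O)c1c(NC(=O)c2ccccc2Cl)sc2c1CCN(Cc1ccccc1Cl)C2`, gives 4430 nM
compound 2, `NC(=O)c1c(NC(=O)c2ccccc2F)sc2c1CCN(Cc1c(Cl)cccc1Cl)C2`, gives 7430 nM
compound 3, `NC(=O)c1c(NC(=O)c2ccccc2F)sc2c1CCN(Cc1ccc(Cl)cc1Cl)C2`, gives 9610 nM

Compound 1 has the lowest number of the three. Compound 2 sits within the scatter of it, while compound 3 lies beyond it. For the measured compounds named here, the only single-point step among the measured compounds is a 1.3-fold higher number from compound 2 to compound 3 (0.11 log units; within the scatter), which concerns the substitution pattern of a benzyl group and nothing else.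

Compound 4, `NC(=O)c1c(NC(=O)c2ccccc2Cl)sc2c1CCN(C(=S)Nc1ccccc1F)C2`, departs from compound 1 by a different kind of change: a group of 10 heavy atoms (7 carbon, 1 nitrogen, 1 fluorine, 1 sulfur; one six-membered aromatic ring of carbon only) in place of a group of 8 heavy atoms (7 carbon, 1 chlorine; one six-membered aromatic ring of carbon only), on an amine nitrogen in a ring. Going by the values given here, no measured step bears on this change, since compound 2 and compound 3 both keep a benzyl group on the ring nitrogen and differ from compound 1 elsewhere. Among the compounds with values here, the one step seen, a 1.3-fold higher number from compound 2 to compound 3 (0.11 log units; within the scatter), stays inside the scatter and gives no direction for a change of this size. The expectation for compound 4 is therefore a number close to that of compound 1, with a wide range, as the step of a 1.1-fold higher number from compound 1 to compound 4 (0.05 log units; within the scatter). Compound 4 is estimated at 5000 nM, between 1200 nM and 20000 nM.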

Compound 4, half-maximal inhibitory concentration: 12600 nM
Estimate against measurement, compound 4: 2.5-fold (0.40 log units) below; the range from low to high includes it.
By their numbers in this assay, from the lowest: compounds 1, 2, 3 and 4 (each within the scatter of the next, the first and the last beyond it).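

At an amine nitrogen in a ring, the thiourea group in place of 2-chlorobenzyl brings a 2.8-fold higher number from compound 1 to compound 4 (0.45 log units; beyond the scatter) in this assay. For the compounds shown here, this is the first look at a group other than a substituted benzyl on this nitrogen, and it shows that the position responds to what it carries, though the step is only modest and leaves compound 4 with a measurable number. No supporting measurement on the compounds speaks to why the number moves.

The single change replaces the link and the ring substituent together, so the compounds shown do not separate the thiourea link from the fluorine on its ring. As far as these compounds go, how a urea, with oxygen in place of the sulfur, or a short alkyl chain on the same nitrogen would read in this assay stays open.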